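This account rests on a few compounds, and the source may have more. Where it says the series, first, only, none or still open, it means among the compounds named here.

Two compounds of the series have a number in a physicochemical assay for solubility, read by HPLC, measured as thermodynamic solubility, with a stated time of 4 h, at pH 6.8; on this read-out lower numbers stand for lower solubility and higher numbers for higher solubility. Compound 1 `Cn1c(COc2cccc(C(=O)O)c2)nc2ccc(Oc3ncccc3Cl)cc21` gives 15 ug/mL in this assay. Going by the values given here, compound 2 `Cn1c(COc2cccc(C(=O)O)c2)nc2ccc(Oc3ccc(F)cn3)cc21` gives 79 ug/mL in this assay, the higher of the two numbers, and the single step between them, a 5.3-fold higher number from compound 1 to compound 2 (0.72 log units; beyond the scatter), is the only one measured so far.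

Compound 3 `Cc1cc(F)cnc1Oc1ccc2nc(COc3cccc(C(=O)O)c3)n(C)c2c1` differs from compound 2 by one change: methyl in place of hydrogen on an aromatic carbon. Among the compounds with values here, no measured step changes a methyl or touches that carbon, so the one step seen, from a chloro to a fluoro pyridine, does not bear directly on it. In this assay a step of this kind is therefore expected to be small, toward a lower number or none beyond the scatter, and the estimate for compound 3 implies a 1.8-fold lower number from compound 2 to compound 3 (0.24 log units; within the scatter). Compound 3 is expected to give about 45 ug/mL in this assay, within 15 ug/mL to 130 ug/mL.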

Compound 3, solubility: 14 ug/mL
The estimate for compound 3 lay 3.2-fold (0.51 log units) above the measured number, and the stated range ends above it.
By their numbers in this assay, from the lowest: compounds 3 and 1 (each within the scatter of the next); then compound 2.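

In this assay, methyl in place of hydrogen on this aromatic carbon, ortho to a large group and two atoms from the ring nitrogen, gives a 5.6-fold lower number from compound 2 to compound 3 (0.75 log units; beyond the scatter) and so shows that even a single added carbon at this place can move the number beyond the scatter. The step of 5-fluoro-3-methylpyridin-2-yl in place of 3-chloropyridin-2-yl gives a 1.1-fold lower number from compound 1 to compound 3 (0.03 log units; within the scatter) and leaves compound 2, with hydrogen on this carbon, alone at the higher number, so the 5-fluoro group does not by itself go with that number. No measurement in hand accounts for these steps.

Open, going by these compounds, is whether an amine, a methoxy group or a longer chain on this carbon would read like compound 2 or like compound 3. Also open, on these data alone, is whether the methyl step holds on a pyridine without the fluoro group.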